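This account rests on a few compounds, and the source may have more. Where it says the series, first, only, none or still open, it means among the compounds named here.

In an ADME assay on MT4 cells (Homo sapiens) for cytotoxicity, read by MTT assay, with a stated time of 5 days (on this read-out lower numbers stand for higher toxicity in this test and higher numbers for lower toxicity in this test), compound 1 `Cc1cc(C)cc(S(=O)(=O)c2c(C(N)=O)[nH]c3ccc(Cl)cc23)c1` gives 13000 nM and compound 2 `Cc1cc(C)cc(S(=O)(=O)c2c(C(=O)NC3CN(Cc4cccnc4)C3)[nH]c3ccc(Cl)cc23)c1` gives 36000 nM. Compound 3 `Cc1cc(C)cc(S(=O)(=O)c2c(C(=O)NC3CN(S(C)(=O)=O)C3)[nH]c3ccc(Cl)cc23)c1` gives > 252000 nM, which is a limit and not a number. Compound 4 `CCS(=O)(=O)NC(=O)c1[nH]c2ccc(Cl)cc2c1S(=O)(=O)c1cc(C)cc(C)c1` differs from compound 3 at one place: ethylsulfonyl in place of 1-(methylsulfonyl)azetidin-3-yl on an amide-type nitrogen. Ethylsulfonyl thus stands in place of 1-(methylsulfonyl)azetidin-3-yl on an amide-type nitrogen.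

Among the compounds with values here, three measured steps bear on this change. Replacing the amide hydrogen gave a 2.8-fold higher number from compound 1 to compound 2 (0.44 log units; beyond the scatter) and an at least 19-fold higher number from compound 1 to compound 3 (1.28 log units; beyond the scatter), so both substituents raised the number, by modest and large amounts. Changing only the group on the ring nitrogen gave an at least 7.0-fold higher number from compound 2 to compound 3 (0.84 log units; beyond the scatter), so the size of the rise depends on the group carried. None of these steps tests a sulfonyl group placed directly on the amide-type nitrogen, and the expectation is correspondingly loose. Compound 4 is expected to keep a higher number than compound 1, but a lower one than compound 3. The expected change is an at least 4.2-fold lower number from compound 3 to compound 4 (0.62 log units; beyond the scatter), a modest to large move towards a lower number. For compound 4 the estimate is 60000 nM, with an expected range of 15000 nM to 240000 nM.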

Compound 4, half-maximal cytotoxic concentration: > 283000 nM
Compound 4: only a limit was reported (the forecaster's own chance of this, stated with the estimate: 30%); at least 4.7-fold (0.67 log units) between middle value and limit.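

In this assay, ethylsulfonyl on the amide-type nitrogen gives an at least 21-fold higher number from compound 1 to compound 4 (1.33 log units; beyond the scatter), and in place of 1-((pyridin-3-yl)methyl)azetidin-3-yl it gives an at least 7.8-fold higher number from compound 2 to compound 4 (0.89 log units; beyond the scatter). The rise therefore does not need the four-membered ring of compound 3, since compound 4, whose group on this nitrogen has no ring, also ends at a limit of the assay. Compound 4 is known only as a limit, as is compound 3, so the step between them cannot be read: the limit of > 283000 nM in this assay, at which 1 of the 4 values shown sits.

Where the true values of compound 3 and compound 4 lie stays open, and with it any order between their two groups. Also open, going by these compounds, is whether an ethyl chain on the amide-type nitrogen, without the sulfonyl, would keep the number this high.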